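Alkoxy chain length in an aryl carbamate series

The compounds below may be only part of what the source reports. "The series", "measured", "known", "first", "only" and "open" are said of these compounds alone.

Measured compounds:
compound 1, `CCCCOc1ccc(C(CC)NC(=O)Oc2cccc(C(F)(F)F)c2)cc1`, 51 nM
compound 2, `CCCCOc1ccc(C(CC)NC(=O)Oc2ccc(OC)cc2)cc1`, 12 nM
compound 3, `CCCCCOc1ccc(NC(=O)ON=C(C)C)cc1`, 28 nM

In an assay on H4 cells for inhibition of Fatty-acid amide hydrolase 1 (Homo sapiens) (a lower number here means a stronger inhibitor, a higher number a weaker inhibitor), compound 3 gives 28 nM, the second highest of the three numbers. Its gap to compound 1 is within the scatter; its gap to compound 2 lies beyond it, compound 2 giving the lower number. Compound 4, `CCCCCCCCCCCCOc1ccc(NC(=O)ON=C(C)C)cc1`, differs from compound 3 by heptyl in place of hydrogen on a saturated chain carbon, five bonds along the chain from an oxygen on an aromatic ring. Among the measured compounds shown here, no measured pair shows a change of this kind, so the data fix neither the size nor the direction of the step. The carbamate end of the molecule is unchanged, and no step beyond the scatter is expected in either direction. Compound 4 is estimated at 22 nM, with a range of 6 nM to 80 nM. The expected step from compound 3 to compound 4 is a 1.3-fold lower number from compound 3 to compound 4 (0.10 log units; within the scatter).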

Compound 4, half-maximal inhibitory concentration: 5 nM
For compound 4 the middle estimate is 4.4-fold (0.64 log units) above the measured one; measured number below the stated range.
By their numbers in this assay, from the lowest: compound 4; then compound 2; then compounds 3 and 1 (each within the scatter of the next).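

In this assay, among the compounds shown here, heptyl in place of hydrogen on a saturated chain carbon, five bonds along the chain from an oxygen on an aromatic ring, gives a 5.6-fold lower number from compound 3 to compound 4 (0.75 log units; beyond the scatter) as the first single-change step. This position therefore tolerates the added chain, and the step runs toward stronger inhibition, though a single pair sets no trend. No measurement here bears on the origin of this step.

On these data alone, with only these two chains on this carbamate, the course of the change at intermediate lengths stays open. Also open, as far as these compounds go, is whether a longer chain, or a carboxylic acid at the chain end, would keep the gain.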